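Triazole series: chloro added to the phenoxy ring

This account rests on a few compounds, and the source may have more. Where it says the series, first, only, none or still open, it means among the compounds named here.

Measured compounds in an assay on isolated protein for inhibition of Aromatase (Homo sapiens), read by fluorescence and colorimetric assay, with a stated time of 30 min; a lower number here means a stronger inhibitor, a higher number a weaker inhibitor:
compound 1 `N#Cc1ccc(C(c2ccc(C#N)cc2)n2cc(COc3ccc(Cl)cc3)nn2)cc1`, 16100 nM
compound 2 `CCCCCCCc1cn(Cc2ccc(C#N)cc2)nn1`, 3070 nM
compound 3 `N#Cc1ccc(Cn2cc(COc3ccccc3)nn2)cc1`, 6090 nM

Compound 3 stands second highest of the three numbers in this assay. Its nearest neighbour is compound 2, whose value is 3070 nM, a difference within the scatter; its furthest is compound 1, whose value is 16100 nM, a difference beyond the scatter.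

Compound 4 `N#Cc1ccc(Cn2cc(COc3ccc(Cl)cc3)nn2)cc1` differs from compound 3 in one place: chloro in place of hydrogen on an aromatic carbon. The only step shown, a 2.0-fold higher number from compound 2 to compound 3 (0.30 log units; within the scatter), concerns a different part of the molecule and does not bear directly on this change. Compound 1 also carries the chlorophenoxy group, but it differs from compound 3 in more than one place, so its value says nothing clean about the chloro alone. Going by the values given here, with no step on this change, the expectation for compound 4 in this assay is a step of about a 1.1-fold lower number from compound 3 to compound 4 (0.04 log units; within the scatter), meaning nothing beyond the scatter. The estimate for compound 4 is 5500 nM, with a range from 2000 nM to 15000 nM.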

Compound 4, half-maximal inhibitory concentration: 3910 nM
Compound 4: the middle estimate sits 1.4-fold (0.15 log units) above what was measured; measured number inside the range.
By their numbers in this assay, from the lowest: compounds 2, 4 and 3 (each within the scatter of the next); then compound 1.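

In this assay, going by these compounds alone, this is the first reading on the phenoxy ring itself: phenyl to 4-chlorophenyl, with the chloro on an aromatic carbon para to a large group, gives (a 1.6-fold lower number from compound 3 to compound 4 (0.19 log units; within the scatter)), so this change moves the number by nothing beyond the scatter. Within the data shown here, with the chlorophenoxy group held constant, the pair also isolates the substituent on the saturated chain carbon bound to the triazole nitrogen: hydrogen in place of 4-cyanophenyl gives (a 4.1-fold lower number from compound 1 to compound 4 (0.61 log units; beyond the scatter)), a modest step beyond the scatter and the only such step on this change. No measurement at hand explains either step.

From the compounds shown here alone, it remains open whether a methoxy group, a bromo group or a carboxylic acid in place of the chloro would give a step beyond the scatter. It is also open whether the chloro would read the same with 4-cyanophenyl present, since compound 1 has no unchlorinated partner among the compounds shown.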